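From Isopropoxy to Chloro on the Amide Aryl Ring

This account rests on a few compounds, and the source may have more. Where it says the series, first, only, none or still open, it means among the compounds named here.

Compound 2 `CC(C)Oc1cccc(NC(=O)CN2CCC(c3cccc[n+]3[O-])CC2)c1` stands lowest of the three measured compounds in a functional assay on HEK293 cells for agonist activity at D(4) dopamine receptor (Homo sapiens), read by FLIPR (on this read-out higher numbers stand for larger maximal responses and lower numbers for smaller maximal responses), giving 48%. For the measured compounds named here, compound 1 `Cc1cccc(C(=O)NCN2CCC(c3ccccn3)CC2)c1` gives 67% and compound 3 `Cc1cccc(C(=O)NCN2CCC(c3cccc[n+]3[O-])CC2)c1` gives 77% in this assay; the only step between measured compounds that differ in one place, a number 10 percentage points higher from compound 1 to compound 3 (within the scatter), concerns a different part of the molecule. Compound 4 `O=C(CN1CCC(c2cccc[n+]2[O-])CC1)Nc1cccc(Cl)c1` differs from compound 2 by chloro in place of isopropoxy on an aromatic carbon. Going by the values given here, no measured step touches this position, so the change from compound 2 has no direct precedent here, and nothing beyond the scatter is expected from it. Compound 4 is therefore expected to change little, with an estimated step of a number 7 percentage points higher from compound 2 to compound 4 (within the scatter) and an estimated value of 55%, ranging from 35% to 75%.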

Compound 4, largest response reached (reported as efficacy), in percent of the reference or control that the assay uses: 76%
For compound 4 the middle estimate is 21 percentage points below the measured one, and the stated range ends below it.
By their numbers in this assay, from the lowest: compound 2; then compounds 1, 4 and 3 (each within the scatter of the next).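

The position, an aromatic carbon meta to a large group, proves sensitive to what it carries: in this assay, chloro in place of isopropoxy gives a number 28 percentage points higher from compound 2 to compound 4 (beyond the scatter). For the compounds shown here, the earlier compounds held no step at this place, so this is the first sign that the maximal response depends on the group here. Nothing given here accounts for the size of this step.

The compounds shown leave open how methoxy, fluoro or an amine on the same carbon would compare with chloro and isopropoxy. One pair also cannot tell whether the step comes from the entry of chloro or the departure of isopropoxy.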